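Replacing acetamido with (butoxycarbonyl)amino in the series

The source may hold more compounds than are shown below. What is called first, only, known or untested is meant among the compounds shown, and "the series" means these compounds.

In a functional assay on aorta (Rattus norvegicus, strain Sprague-Dawley) (a higher number here means that more compound is needed for the effect, a lower number that less compound is needed), compound 1 `Cc1nn(-c2ccccc2)c2nc(OCc3ccccc3F)c(-c3nc(N)cc(N)n3)cc12` gives 2200 nM. Within the data shown here, compound 2 `CC(=O)Nc1c(N)nc(-c2cc3c(C)nn(-c4ccccc4)c3nc2OCc2ccccc2F)nc1N`, with acetamido in place of hydrogen on an aromatic carbon, gives 930 nM, the lower of the two numbers so far. That change is a 2.4-fold lower number from compound 1 to compound 2 (0.37 log units; beyond the scatter), a modest step beyond the scatter.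

The next structure is compound 3 `CCCCOC(=O)Nc1c(N)nc(-c2cc3c(C)nn(-c4ccccc4)c3nc2OCc2ccccc2F)nc1N`, which has butoxy in place of methyl on a carbonyl carbon. The same difference reads acetamido to (butoxycarbonyl)amino.

Among the measured compounds shown here, no measured pair varies the group on this carbonyl carbon, so direct evidence is lacking. For the measured compounds named here, the only step with any bearing is a 2.4-fold lower number from compound 1 to compound 2 (0.37 log units; beyond the scatter), which introduced the acetamido group now being altered. It gives a rough scale for changes at this place, but no direction for the new one. In this assay no step beyond the scatter is therefore expected, although a modest shift either way would not be surprising. The expected step is a 1.2-fold lower number from compound 2 to compound 3 (0.07 log units; within the scatter). The estimate for compound 3 is 800 nM, with an expected range of 250 nM to 2500 nM.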

Compound 3, half-maximal effective concentration: > 100000 nM
Compound 3 was reported as a limit (the forecaster's own chance of this, stated with the estimate: 5%); at least 120-fold (2.09 log units) between middle value and limit.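

In this assay compound 3 is reported as a limit and not as a number: the limit of > 100000 nM in this assay, at which 1 of the 3 values shown sits.

Among these compounds, the group on this carbonyl carbon, which no earlier pair varied, carries far more weight than the first change at this place suggested: butoxy in place of methyl gives an at least 100-fold higher number from compound 2 to compound 3 (2.03 log units; beyond the scatter), set against the modest 2.4-fold lower number from compound 1 to compound 2 (0.37 log units; beyond the scatter). A substituent on this aromatic carbon therefore does not lower the number as such, since (butoxycarbonyl)amino in place of hydrogen gives an at least 45-fold higher number from compound 1 to compound 3 (1.65 log units; beyond the scatter), the opposite direction to the acetamido change.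

Butoxy brings its oxygen and its chain length together, so the compounds shown cannot say which of the two goes with the large step. A methoxy group on the same carbonyl carbon, or a plain pentyl chain there, would separate the two, and an amine in that place would show whether the step depends on the chain at all.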